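Lengthening the Alkyl Chain in a Series Without Measurable Activity

This account rests on a few compounds, and the source may have more. Where it says the series, first, only, none or still open, it means among the compounds named here.

Of the compounds shown here, three have been measured in a functional assay on Huh-7 cells (Homo sapiens) for inhibition, read by MTT assay, with a stated time of 48 h; on this read-out higher numbers stand for weaker inhibition and lower numbers for stronger inhibition.
Compound 1, `Cc1ccc(Oc2c(/C=N/OCc3snnc3C)c(C)nn2C)cc1`, gives > 50000 nM, which is a limit of the assay and not a number.
Compound 2, `CCc1nnsc1CO/N=C/c1c(C)nn(C)c1Oc1ccccc1Cl`, gives > 50000 nM, also a limit.
Compound 3, `CCc1nnsc1CO/N=C/c1c(C)nn(C)c1Oc1ccc(C)cc1`, gives > 50000 nM, also a limit.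

Going by the values given here, because every value sits at the limit (the limit of > 50000 nM in this assay, at which 3 of the 3 values shown sit), no step between them can be sized. The change methyl in place of hydrogen on a saturated chain carbon bound to an aromatic carbon gives a step that the two limits leave unreadable from compound 1 to compound 3. The change from compound 2 to compound 3, 4-methylphenyl in place of 2-chlorophenyl on an oxygen on an aromatic ring, gives a step that the two limits leave unreadable from compound 2 to compound 3. The difference between the cores of compound 1 and compound 2 is not broken down here.

Compound 4, `CCCc1nnsc1CO/N=C/c1c(C)nn(C)c1Oc1ccccc1Cl`, is not yet measured. It differs from compound 2 by methyl in place of hydrogen on a saturated chain carbon, two bonds along the chain from an aromatic carbon. This is the same kind of change as that from compound 1 to compound 3, but not the same: there the methyl enters on a saturated chain carbon bound to an aromatic carbon, here on a saturated chain carbon two bonds along the chain from an aromatic carbon. Since that earlier step, a step that the two limits leave unreadable from compound 1 to compound 3, left the read-out at the limit (the limit of > 50000 nM in this assay, at which 3 of the 3 values shown sit), compound 4 is expected to remain at the limit as well, an expected step that the limit leaves unreadable from compound 2 to compound 4. The estimate for compound 4 is 80000 nM, expected to lie between 30000 nM and 300000 nM.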

Compound 4, half-maximal inhibitory concentration: > 50000 nM
Compound 4: no number, only a limit (the forecaster's own chance of this, stated with the estimate: 85%); the middle value lies beyond the limit too.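

In this assay compound 4 gives > 50000 nM, which is a limit of the assay and not a number. Compound 2 also stands at a limit, so the change from ethyl to propyl between compound 2 and compound 4 gives no readable step: the limit of > 50000 nM in this assay, at which 4 of the 4 values shown sit.

The compounds shown leave open whether any change to this series would give a measurable value in this assay.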